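Aryl substituent change on a sulfamide piperidine pyrimidine series

The source may report more compounds than this note shows. Statements on the series, on what has been measured and on what is new or still open speak of the compounds shown alone.

Measured so far in a functional assay on HT-29 cells (Homo sapiens) for antiproliferative activity, read by sulforhodamine B assay, with a stated time of 48 h; on this read-out lower numbers stand for stronger inhibition of growth and higher numbers for weaker inhibition of growth:
compound 1 `Cc1ccc(-c2cc(N3CCC(CNS(N)(=O)=O)CC3)ncn2)cc1`, 33900 nM;
compound 2 `NS(=O)(=O)NCC1CCN(c2cc(-c3cccc(Cl)c3)ncn2)CC1`, 47500 nM;
compound 3 `Cc1ccc(-c2cc(N3CCC(CCNS(N)(=O)=O)CC3)ncn2)cc1`, 52300 nM.

Compound 3 lies within the scatter of the others: a 1.5-fold higher number from compound 1 to compound 3 (0.19 log units; within the scatter), and compound 2 gives 47500 nM while compound 3 gives 52300 nM. Compound 4 `CCOC(=O)c1ccc(-c2cc(N3CCC(CCNS(N)(=O)=O)CC3)ncn2)cc1` differs from compound 3 by ethoxycarbonyl in place of methyl on an aromatic carbon. Going by the values given here, the only measured step that touches the aromatic substituent is a 1.4-fold higher number from compound 1 to compound 2 (0.15 log units; within the scatter), which stayed within the scatter. Among the compounds with values here, no step yet tests an ethoxycarbonyl group, so the expectation rests on this single flat step. The step from compound 3 to compound 4 in this assay is estimated as a 1.0-fold lower number from compound 3 to compound 4 (0.02 log units; within the scatter), that is, no movement beyond the scatter in either direction. Compound 4 is therefore expected to give about 50000 nM, with a range from 20000 nM to 120000 nM.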

Compound 4, concentration for 50% growth inhibition: 6800 nM
Compound 4: the middle estimate sits 7.4-fold (0.87 log units) above what was measured, and the stated range ends above it.
By their numbers in this assay, from the lowest: compound 4; then compounds 1, 2 and 3 (each within the scatter of the next).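

With ethoxycarbonyl in place of methyl on this aromatic carbon, para to a large group, the series gives a 7.7-fold lower number from compound 3 to compound 4 (0.89 log units; beyond the scatter) in this assay. The earlier aryl step, a 1.4-fold higher number from compound 1 to compound 2 (0.15 log units; within the scatter), had stayed flat, so this position does respond to at least one substituent. No evidence at hand bears on the reason for this drop.

From the compounds shown here alone, whether the drop belongs to ethoxycarbonyl as such stays open; a carboxylic acid or a primary amide on the same carbon would test this. Also open, going by these compounds, is whether ethoxycarbonyl acts alike on the side chain of compound 1.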